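Extending the Aryl Sulfonyl Group on a Shared Core

This account rests on a few compounds, and the source may have more. Where it says the series, first, only, none or still open, it means among the compounds named here.

Three compounds have so far been measured in a functional assay on PC-3 cells (Homo sapiens) for inhibition; a higher number here means a weaker inhibitor, a lower number a stronger inhibitor:

compound 1 `COc1cc2nc(N3CCN(C(=O)OCc4ccccc4)CC3)nc(N)c2cc1OC`: 63000 nM
compound 2 `COc1ccc(C(=O)N2CCN(c3nc(N)c4cc(OC)c(OC)cc4n3)CC2)cc1OC`: 71000 nM
compound 3 `COc1cc2nc(N3CCN(S(=O)(=O)c4ccc(Cl)cc4)CC3)nc(N)c2cc1OC`: 23000 nM

All three share the same core and differ only in the group capping the ring nitrogen. Within the data shown here, compound 3 gives the lowest number of the three, and its lead over the others is beyond the scatter; the step of a 2.7-fold lower number from compound 1 to compound 3 (0.44 log units; beyond the scatter) is the only change among the measured compounds that moved the number, while a 1.1-fold higher number from compound 1 to compound 2 (0.05 log units; within the scatter) stayed within the scatter.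

Compound 4 `COc1cc2nc(N3CCN(S(=O)(=O)c4ccc(-c5ccc(C(F)(F)F)cc5)cc4)CC3)nc(N)c2cc1OC` keeps the sulfonyl cap of compound 3 and alters only the aryl ring attached to it: 4-(trifluoromethyl)phenyl in place of chloro on an aromatic carbon.

Neither measured step speaks directly to this change. Among the measured compounds shown here, both concern the cap itself, not a substituent on its aromatic ring, so there is no measured precedent for what a larger group at this place does. For the measured compounds named here, the only anchor is the value of compound 3, and the series as a whole sits at weak inhibition. Compound 4 is therefore expected to land near compound 3, with a step of a 1.5-fold lower number from compound 3 to compound 4 (0.19 log units; within the scatter) that may well fall within the scatter. The estimate for compound 4 is 15000 nM, with a range from 4000 nM to 60000 nM.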

Compound 4, half-maximal inhibitory concentration: 3300 nM
Compound 4: middle estimate off by 4.5-fold (0.66 log units), on the high side; measured number below the stated range.
By their numbers in this assay, from the lowest: compound 4; then compound 3; then compounds 1 and 2 (each within the scatter of the next).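

In this assay, the aryl ring of the sulfonyl cap proves to be a place where the number responds to a substituent: a 7.0-fold lower number from compound 3 to compound 4 (0.84 log units; beyond the scatter) is the largest single change among the compounds shown. The earlier steps shown here swapped one cap for another and could not show this, whereas this one keeps the sulfonyl cap and replaces only chloro, a single heavy atom, with 4-(trifluoromethyl)phenyl, which brings 10 heavy atoms and a further six-membered aromatic ring. Far from costing anything, so large an addition at this place goes with a clearly lower number, though no measurement among those shown accounts for the gain.

The compounds shown do not separate the contribution of the added ring from that of the trifluoromethyl group on it, a question that a plain phenyl, or a phenyl carrying a methoxy group, an amine or a carboxylic acid in place of trifluoromethyl, would address. From the compounds shown here alone, it also remains open whether the same 4-(trifluoromethyl)phenyl group would lower the number on the carbonyl caps of compound 1 and compound 2, or only on the sulfonyl cap.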